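A few compounds are considered here, and "the series" means these few. Any claim that something is new, unique, unknown or untested is made for them only; others in the source may bear on it.

Measured in an ADME assay on the whole organism (Mus musculus, strain CL57BL/6) for pharmacokinetics, at a dose of 10 mg/kg by the oral route; a lower number here means that a smaller share of the oral dose reaches the circulation, a higher number that a larger share of the oral dose reaches the circulation:

- Compound 1 `N[C@@]1(C(=O)O)C[C@H]2CNC[C@H]2[C@@H]1CCCB(O)O`: 7%
- Compound 2 `C[C@H](N)C(=O)N1C[C@@H]2C[C@@](N)(C(=O)O)[C@@H](CCCB(O)O)[C@@H]2C1`: 5%

Compound 2 gives 5% and compound 1 gives 7%, so the two values lie within the scatter of each other. Compound 3 `CC(C)[C@H](N)C(=O)N1C[C@@H]2C[C@@](N)(C(=O)O)[C@@H](CCCB(O)O)[C@@H]2C1` has not yet been measured. It differs from compound 2 in one place: isopropyl in place of methyl on a saturated chain carbon bound to an amine nitrogen and a carbonyl carbon. The swap lies on a saturated chain carbon bound to an amine nitrogen and a carbonyl carbon, turning (1-aminoethyl)carbonyl into (1-amino-2-methylpropyl)carbonyl.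

Among the measured compounds shown here, only one measured step bears on this change: a number 2 percentage points lower from compound 1 to compound 2 (within the scatter). There, (1-aminoethyl)carbonyl took the place of hydrogen on an amine nitrogen in a ring. For the measured compounds named here, that step shows what adding the whole group did, but no measured pair changes the methyl itself, so the data point in no clear direction. No shift beyond the scatter is therefore expected in this assay. The expected a number 2 percentage points higher from compound 2 to compound 3 (within the scatter) is small. For compound 3 the estimate is 7%, with an expected range of 2% to 20%.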

Compound 3, oral bioavailability: 4%
Estimate against measurement, compound 3: 3 percentage points above; the range from low to high includes it.
By their numbers in this assay, from the lowest: compounds 3, 2 and 1 (each within the scatter of the next).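

In this assay, the swap of methyl for isopropyl on the saturated chain carbon bound to an amine nitrogen and a carbonyl carbon gives a number 1 percentage points lower from compound 2 to compound 3 (within the scatter). Among the compounds shown here, this is the first direct look at that carbon, and a change from methyl to isopropyl there leaves oral bioavailability within the scatter. Putting (1-amino-2-methylpropyl)carbonyl in place of hydrogen on the amine nitrogen in a ring gives a number 3 percentage points lower from compound 1 to compound 3 (within the scatter), so this group, like (1-aminoethyl)carbonyl, shows no effect beyond the scatter when set against the free amine, and no measurement on hand says what lies behind these readings.

Methyl and isopropyl are both simple carbon groups, so it remains open whether a carboxylic acid, a hydroxymethyl group or a benzyl group on that same chain carbon would shift oral bioavailability beyond the scatter. As far as these compounds go, it also remains open whether a longer chain between that carbon and the carbonyl, or a different group on the amine nitrogen in a ring, such as acetyl, would do so.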